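The source may hold more compounds than are shown below. What is called first, only, known or untested is meant among the compounds shown, and "the series" means these compounds.

Of the compounds shown here, two have been measured in a functional assay on MCF7 cells (Homo sapiens) for inhibition, read by sulforhodamine B assay, with a stated time of 48 h; a higher number here means a weaker inhibitor of growth, a lower number a stronger inhibitor of growth. Compound 1, `COc1ccc(/C=C/C2CC(=O)C=CO2)cc1OC`, gives 130 uM. Compound 2, `O=c1ccoc(/C=C/c2ccccc2)c1`, gives 691 uM, the highest of the two numbers and therefore the weakest growth inhibitor seen so far; its distance from compound 1 lies beyond the scatter of repeated measurements. The two share the styryl linkage but differ in their core and in the substituents on the phenyl ring, so no single change separates them.

Compound 3, `COc1ccc(/C=C/c2cc(=O)cco2)cc1`, has not yet been measured. It differs from compound 2 in one place: methoxy in place of hydrogen on an aromatic carbon. For the measured compounds named here, no step between measured compounds isolates this change. A modest step toward stronger inhibition is expected, a 2.0-fold lower number from compound 2 to compound 3 (0.30 log units; within the scatter), partly because compound 1 carries methoxy groups and gives 130 uM, although its different core keeps that comparison loose. Compound 3 is therefore estimated at 350 uM, within a range from 120 uM to 900 uM.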

Compound 3, concentration for growth inhibition (reported as GI): 396 uM
For compound 3 the middle estimate is 1.1-fold (0.05 log units) below the measured one; the measured number falls inside the stated range.
By their numbers in this assay, from the lowest: compound 1; then compounds 3 and 2 (each within the scatter of the next).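

In this assay, for the compounds shown here, the change of hydrogen to methoxy on an aromatic carbon, para to a group of 9 heavy atoms, gives a 1.7-fold lower number from compound 2 to compound 3 (0.24 log units; within the scatter) and this is the first pair that isolates a single change. On this one pair, a single methoxy at this position produces no clear shift in growth inhibition in either direction. Nothing on hand offers an explanation for this result.

On these data alone, whether a different group at the same position, such as an amine, a carboxylic acid or a longer chain like butoxy, would give a step beyond the scatter remains open. Going by these compounds alone, also open is whether methoxy on another carbon of the aromatic ring, or a second methoxy added to the one in compound 3, would change the number any further.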